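Amine variation on the shared core: towards compound 3

The compounds below may be only part of what the source reports. "The series", "measured", "known", "first", "only" and "open" are said of these compounds alone.

Of the compounds shown here, two have numbers so far in an assay on HEK293 cells for displacement of a labelled ligand from corticotropin-releasing factor receptor 1 (Homo sapiens), with a stated time of 2 h; a higher number here means a weaker inhibitor, a lower number a stronger inhibitor. Compound 1 `CCCN(CCC)c1ccc(C)c2nc(-c3c(OC)cc(COC)cc3OC)c(C)cc12` gives 88 nM, and compound 2 `COCc1cc(OC)c(-c2nc3c(C)ccc(N(CC4CCOCC4)CC4CC4)c3cc2C)c(OC)c1` gives 286 nM. Going by the values given here, compound 2 therefore stands at the higher of the two numbers, its only neighbour being compound 1, separated by a 3.3-fold higher number from compound 1 to compound 2 (0.51 log units; beyond the scatter). The next compound, compound 3 `CCC(CC)Nc1ccc(C)c2nc(-c3c(OC)cc(COC)cc3OC)c(C)cc12`, keeps the core of compound 2 and alters only the amine: (pentan-3-yl)amino in place of (cyclopropylmethyl)((oxan-4-yl)methyl)amino on an aromatic carbon. Among the compounds with values here, no measured step matches this change exactly. Within the data shown here, the one step that bears on it, a 3.3-fold higher number from compound 1 to compound 2 (0.51 log units; beyond the scatter), went from a small open-chain amine to the larger, ring-bearing one, and the number rose modestly. The change to compound 3 runs the other way, back to a smaller, ring-free amine, so a step of about that size downward in this assay is expected, placing compound 3 roughly where compound 1 sits. For compound 3 the estimate is 110 nM, with a range of 40 nM to 320 nM, which is expected to mean a step of a 2.6-fold lower number from compound 2 to compound 3 (0.41 log units; beyond the scatter).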

Compound 3, half-maximal inhibitory concentration: > 1000 nM
Compound 3: no number, only a limit (the forecaster's own chance of this, stated with the estimate: 2%); middle value at least 9.0-fold (0.95 log units) from the limit.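

In this assay the reading for compound 3 is a limit of the assay and not a number: the limit of > 1000 nM in this assay, at which 1 of the 3 values shown sits.

Even so, the steps can be read in one direction: the change at this aromatic carbon, para to a methyl group, gives an at least 3.4-fold higher number from compound 2 to compound 3 (0.54 log units; beyond the scatter), and the comparison with dipropylamino gives an at least 11-fold higher number from compound 1 to compound 3 (1.05 log units; beyond the scatter). The earlier step alone left open that the smaller, ring-free amine would give the lower number, yet going from 12 heavy atoms to 6, with both rings lost and 1 hydrogen-bond donor entering where there were 0, moves the number up, so size does not order these three amines: the ring-free dipropylamino of compound 1 has the lowest number, and the ring-free (pentan-3-yl)amino of compound 3 sits at the limit.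

The compounds shown do not separate the entering hydrogen-bond donor from the change in the carbon groups on the nitrogen, as both change together in compound 3. As far as these compounds go, a methyl(pentan-3-yl)amino group, which keeps the branched chain and loses the amine hydrogen, would bear directly on that question, and how far compound 3 lies past its limit stays open.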